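The compounds below may be only part of what the source reports. "The series", "measured", "known", "first", "only" and "open" are said of these compounds alone.

Of the compounds shown here, three sharing one core have been tested for how strongly they curb the growth of a human colon-cancer cell line. Compound 1 `COc1cccc(/C=C2\CCC/C(=C\c3ccccc3Br)C2=O)c1OC` gives 12100 nM in a functional assay on SW-620 cells (Homo sapiens) for cytotoxicity, read by MTT assay, with a stated time of 72 h; on this read-out higher numbers stand for weaker inhibition and lower numbers for stronger inhibition. For the measured compounds named here, compound 2 `COc1cccc(/C=C2\CCC/C(=C\c3cc(Cl)cc(Cl)c3)C2=O)c1OC` gives 5500 nM in this assay, and the only measured step, a 2.2-fold lower number from compound 1 to compound 2 (0.34 log units; beyond the scatter), shows a modest change when one aromatic group is swapped for another at the same place. Compound 3 `COc1ccc(/C=C2\CCC/C(=C\c3ccc(Cl)cc3)C2=O)cc1OC` gives 5900 nM in this assay, which puts it second highest of the three numbers, within the scatter of compound 2 and beyond the scatter of compound 1.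

Compound 4 `COc1ccc(/C=C2\CCC/C(=C\c3ccc(O)c(O)c3)C2=O)cc1OC` has not yet been measured. It differs from compound 3 as follows: 3,4-dihydroxyphenyl in place of 4-chlorophenyl on a double-bonded chain carbon bound to a double-bonded ring carbon. Going by the values given here, the single step of a 2.2-fold lower number from compound 1 to compound 2 (0.34 log units; beyond the scatter) is the only guide, and it concerns a different pair of groups, so it shows only that swapping an aromatic group at this place has so far moved the number modestly. A step of about that size, in either direction, is therefore expected as a 1.1-fold higher number from compound 3 to compound 4 (0.04 log units; within the scatter). Compound 4 is estimated at 6500 nM, with a range from 1500 nM to 28000 nM.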

Compound 4, half-maximal inhibitory concentration: 10500 nM
Compound 4: the middle estimate sits 1.6-fold (0.21 log units) below what was measured; measured number inside the range.
By their numbers in this assay, from the lowest: compounds 2, 3, 4 and 1 (each within the scatter of the next, the first and the last beyond it).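

In this assay, the swap of 4-chlorophenyl for 3,4-dihydroxyphenyl gives a 1.8-fold higher number from compound 3 to compound 4 (0.25 log units; within the scatter), so this position can take a group with 2 hydrogen-bond donors and 2 hydrogen-bond acceptors in place of one with 0 of each without a change beyond the scatter. The earlier step involved only halogen-bearing aromatic groups, whereas this one shows that a very different substitution on the aromatic ring can also leave the number within the scatter. No measurement shown here offers an explanation for this result.

Going by these compounds, whether an amine or a carboxylic acid on this aromatic ring would move the number beyond the scatter remains open. On these data alone, it is also open whether 3,4-dihydroxyphenyl would give a similar result on the core of compound 1.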